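A few compounds are considered here, and "the series" means these few. Any claim that something is new, unique, unknown or untested is made for them only; others in the source may bear on it.

Compound 1, `CC[C@H]1CN(c2nc(N)c(C(N)=O)nc2Cl)CCN1C1CCN(C(=O)c2ccc(Cl)cc2)CC1`, gives 76 nM in an in vitro assay on BaF3 cells for displacement of a labelled ligand from C-X-C chemokine receptor type 3 (Homo sapiens); on this read-out lower numbers stand for stronger inhibition and higher numbers for weaker inhibition. Compound 2, `CC[C@H]1CN(c2nc(N)c(C(=O)NCCO)nc2Cl)CCN1C1CCN(C(=O)c2ccc(Cl)nc2N)CC1`, gives 3.4 nM. Compound 3, `CC[C@H]1CN(c2ncc(C(=O)NC3CC3)nc2Cl)CCN1C1CCN(C(=O)c2ccc(Cl)nc2N)CC1`, gives 1.2 nM.

Of these three, compound 3 has the lowest number in this assay; its gap to compound 2 lies beyond the scatter, and its gap to compound 1 is far wider. Compound 4, `CC[C@H]1CN(c2ncc(C(=O)NCCO)nc2Cl)CCN1C1CCN(C(=O)c2ccc(Cl)nc2N)CC1`, differs from compound 3 by 2-hydroxyethyl in place of cyclopropyl on an amide-type nitrogen. Among the measured compounds shown here, no measured pair shows this change by itself, so its size can only be judged indirectly: compound 2 carries the same 2-hydroxyethyl group on the amide-type nitrogen and gives 3.4 nM, a number not far from that of compound 3. A small move toward a higher number, or none beyond the scatter, is expected. Compound 4 is estimated at 2 nM, within 0.7 nM to 6 nM. That estimate means an expected step of a 1.7-fold higher number from compound 3 to compound 4 (0.22 log units; within the scatter).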

Compound 4, half-maximal inhibitory concentration: 2.9 nM
Compound 4: middle estimate off by 1.5-fold (0.16 log units), on the low side, within the range that was stated.
By their numbers in this assay, from the lowest: compound 3; then compounds 4 and 2 (each within the scatter of the next); then compound 1.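

Measured by this assay the swap of cyclopropyl for 2-hydroxyethyl on the amide-type nitrogen gives a 2.4-fold higher number from compound 3 to compound 4 (0.38 log units; beyond the scatter) and so has a real but modest cost. With 2-hydroxyethyl on that nitrogen, hydrogen in place of amino on an aromatic carbon gives a 1.2-fold lower number from compound 2 to compound 4 (0.07 log units; within the scatter) and so makes no clear difference. No available measurement explains either result.

From the compounds shown here alone, what a longer chain, or one ending in an amine or a carboxylic acid, would do on this nitrogen stays open.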